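Swapping the aryl group on a nucleoside transporter inhibitor

The source may hold more compounds than are shown below. What is called first, only, known or untested is meant among the compounds shown, and "the series" means these compounds.

Of the compounds shown here, two have been measured in an assay on isolated protein for binding affinity to Equilibrative nucleoside transporter 1 (Homo sapiens); on this read-out higher numbers stand for weaker inhibition and lower numbers for stronger inhibition. Compound 1 `OC[C@H]1O[C@@H](n2cnc3c(SCC4CCCCC4)ncnc32)[C@H](O)[C@@H]1O` gives 1550 nM. Compound 2 `O=[N+]([O-])c1cccc(SCc2ncnc3c2ncn3[C@@H]2O[C@H](CO)[C@@H](O)[C@H]2O)c1` gives 4.79 nM, the lowest of the two numbers; the gap to compound 1 is far beyond the scatter of repeated measurements, so compound 2 is clearly the stronger inhibitor of the pair. Compound 3 `OC[C@H]1O[C@@H](n2cnc3c(CSc4ccc(F)cc4)ncnc32)[C@H](O)[C@@H]1O` has not been measured yet. It differs from compound 2 in one place: 4-fluorophenyl in place of 3-nitrophenyl on a sulfur. In plain words, a 4-fluorophenyl group replaces the 3-nitrophenyl group on the sulfur, and the two rings that carry the hydrogen-bond acceptors in compound 2 leave with the nitro group. Among the measured compounds shown here, no measured pair shows the effect of such a swap, so the expectation rests on the two values alone. Compound 2 sits at a low value, and a smaller aryl group without the nitro group is expected to weaken inhibition somewhat, giving a step from compound 2 to compound 3 of about a 6.3-fold higher number from compound 2 to compound 3 (0.80 log units; beyond the scatter) in this assay, likely beyond the scatter but far smaller than the gap between compound 1 and compound 2. Compound 3 is therefore estimated at 30 nM, with a range from 8 nM to 150 nM.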

Compound 3, half-maximal inhibitory concentration: 158 nM
Beside the measured number, compound 3's estimate is 5.3-fold (0.72 log units) below it; the whole stated range lies below it.
By their numbers in this assay, from the lowest: compound 2; then compound 3; then compound 1.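

In this assay, among the compounds shown here, the group on the sulfur proves to matter a great deal: 4-fluorophenyl in place of 3-nitrophenyl gives a 33-fold higher number from compound 2 to compound 3 (1.52 log units; beyond the scatter), the first measured change confined to this group, and a large one. Compound 3 still keeps an edge over the compound with the (cyclohexylmethyl)sulfanyl group, with a 9.8-fold lower number from compound 1 to compound 3 (0.99 log units; beyond the scatter), but that step is modest. The whole ((4-fluorophenyl)sulfanyl)methyl chain differs in that step. It cannot be pinned on the ring alone. Why the nitro-bearing ring gives so much the lower number is something the data shown cannot explain.

The step from compound 2 to compound 3 changes two things at once, since the substituent on the ring differs and so does its numbered place, which leaves open whether the nitro group itself or its place at the 3-position carries the difference. A plain phenyl, a 4-nitrophenyl and a 3-fluorophenyl group on the same sulfur would pull these apart, and none of them is among the compounds shown.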